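The source may report more compounds than this note shows. Statements on the series, on what has been measured and on what is new or still open speak of the compounds shown alone.

In a functional assay on MIA PaCa-2 cells (Homo sapiens) for inhibition, read by MTT assay, with a stated time of 72 h (on this read-out higher numbers stand for weaker inhibition of growth and lower numbers for stronger inhibition of growth), compound 1 `CC(C)(C)c1ccc(CNCCCNS(=O)(=O)c2cc(C(F)(F)F)cc(C(F)(F)F)c2)cc1` gives 2300 nM. A related compound, compound 2 `O=S(=O)(NCCCCCCNCc1ccc(Br)cc1)c1ccc(C(F)(F)F)cc1`, gives 3830 nM in this assay; the two values lie within the usual scatter of each other, so neither can be called the stronger inhibitor. Compound 3 `O=S(=O)(NCCCNCc1ccc(Br)cc1)c1cc(C(F)(F)F)cc(C(F)(F)F)c1` has not yet been measured. It differs from compound 1 in one place: bromo in place of tert-butyl on an aromatic carbon. Among the compounds with values here, no measured pair shows this change on its own. A small step is expected, a 1.3-fold higher number from compound 1 to compound 3 (0.12 log units; within the scatter), if anything toward weaker growth inhibition. Compound 3 is therefore estimated at 3000 nM, within a range from 1200 nM to 7500 nM.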

Compound 3, concentration for 50% growth inhibition: 2300 nM
Beside the measured number, compound 3's estimate is 1.3-fold (0.12 log units) above it; the measured number falls inside the stated range.
By their numbers in this assay, from the lowest: compounds 1, 3 and 2 (each within the scatter of the next).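

Placing bromo in place of tert-butyl on this aromatic carbon gives no change at the digits printed from compound 1 to compound 3 (within the scatter) in this assay and provides the first direct reading of this change. For this pair, a single bromine atom and a four-carbon group leave growth inhibition indistinguishable, so tert-butyl is not required at this position in this compound. No separate measurement gives a reason for this result.

Going by these compounds, whether a carboxylic acid or an amine at this position would also leave the value unchanged remains open. So does whether this swap would read the same on a compound with a longer chain.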